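Trimming one methoxy group from a trimethoxy pattern

The compounds below may be only part of what the source reports. "The series", "measured", "known", "first", "only" and "open" are said of these compounds alone.

Compound 1, `COc1ccc(-c2cc(/C=C/C(=O)c3ccc(N)cc3)[nH]n2)cc1`: in a functional assay on OVCAR-8 cells (Homo sapiens) for inhibition, read by sulforhodamine B assay, with a stated time of 48 h (a higher number here means a weaker inhibitor of growth, a lower number a stronger inhibitor of growth), compound 1 gives 15400 nM.
Compound 2, `COc1ccc(-c2cc(/C=C/C(=O)c3ccc(N)cc3)[nH]n2)cc1OC`: in this assay compound 2 gives 10500 nM.
Compound 3, `COc1cc(C(=O)/C=C/c2cc(-c3cc(OC)c(OC)c(OC)c3)n[nH]2)cc(OC)c1OC`: in this assay compound 3 gives 3280 nM.

Compounds 1 and 2 share one core and differ in a single place: hydrogen in place of methoxy on an aromatic carbon. That change gave a 1.5-fold higher number from compound 2 to compound 1 (0.17 log units; within the scatter), so the two numbers cannot be told apart. Compound 3 carries a different arrangement of groups on both ends of the molecule; the difference between its core and that of compound 2 is not broken down here. Its number is the lowest of the three, and its gaps to compound 2 and to compound 1 both lie beyond the scatter.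

Compound 4, `COc1ccc(-c2cc(/C=C/C(=O)c3cc(OC)c(OC)c(OC)c3)[nH]n2)cc1OC`, is not yet measured. It differs from compound 3 by hydrogen in place of methoxy on an aromatic carbon. Within the data shown here, this is the same kind of change as the one from compound 2 to compound 1, though not the same: in compound 3 the carbon that loses its methoxy group is also meta to a methoxy group, which is not so in compound 2. The earlier step from compound 2 to compound 1 stayed within the scatter, and on that the expectation for compound 4 rests: a step of a 1.4-fold higher number from compound 3 to compound 4 (0.14 log units; within the scatter) is expected. Compound 4 is therefore estimated to give about 4500 nM, most likely between 2000 nM and 10000 nM.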

Compound 4, concentration for total growth inhibition: 11700 nM
The estimate for compound 4 lay 2.6-fold (0.41 log units) below the measured number; measured number above the stated range.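

In this assay, putting hydrogen in place of one methoxy group gave a 3.6-fold higher number from compound 3 to compound 4 (0.55 log units; beyond the scatter) and thus a modest but readable loss of growth inhibition on this core. Set beside the same change on the other core, the two steps cannot be told apart, even though only one of them lies beyond the scatter on its own: the same change on two cores in this assay, a 1.5-fold higher number (0.17 log units; within the scatter) from compound 2 to compound 1 and a 3.6-fold higher number (0.55 log units; beyond the scatter) from compound 3 to compound 4, 2.4-fold (0.39 log units) apart, within the scatter of two such steps. Among these compounds, the two pairs therefore do not prove that the change costs more on the core of compound 3, nor do they prove that it costs the same on both cores; with only two cores, no rule for carrying it to a further core follows, and no cause can be named for either step.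

The compounds shown leave open what other groups would do in these places, since the pairs compare only methoxy with hydrogen, and a fluorine atom, a hydroxyl group or an amine could behave differently. They also leave open whether taking further methoxy groups away from compound 4 would raise the number again, and whether the step seen here would look the same in other cells.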